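Trimming a Fluoroethoxy Chain on a Pyridyl Urea

A few compounds are considered here, and "the series" means these few. Any claim that something is new, unique, unknown or untested is made for them only; others in the source may bear on it.

Three compounds with a shared core were tested in a functional assay on HCT-116 cells (Homo sapiens) for cytotoxicity, read by MTT assay, with a stated time of 48 h, in the presence of a further agent that is not named here; a higher number here means that more compound is needed for the effect, a lower number that less compound is needed. Compound 1 `CC(C)c1cc(NNC(=O)Nc2cc(Cl)nc(Cl)c2)nc2c1c(C(F)(F)F)nn2C` gives 27200 nM. Compound 3 `CCCc1cc(NNC(=O)Nc2cc(Cl)nc(Cl)c2)nc2c1cnn2C` gives 76200 nM. Compound 2 `Cn1ncc2c(-c3ccc(F)cc3)cc(NNC(=O)Nc3cc(Cl)nc(OCCF)c3)nc21` gives 37200 nM, the second highest of the three numbers; its gap to compound 1 lies within the usual scatter, while compound 3 sits beyond that scatter with the higher number. Compound 4 `COc1cc(NC(=O)NNc2cc(-c3ccc(F)cc3)c3cnn(C)c3n2)cc(Cl)n1` has not yet been measured. It differs from compound 2 in one place: hydrogen in place of fluoromethyl on a saturated chain carbon bound to an oxygen on an aromatic ring. Going by the values given here, no measured pair shows this exact change, so its effect is unknown here, and only a modest shift, likely within the scatter and without a clear direction, is expected. The expected step is a 1.1-fold lower number from compound 2 to compound 4 (0.03 log units; within the scatter). Compound 4 is estimated at 35000 nM, in a range from 15000 nM to 80000 nM in this assay.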

Compound 4, half-maximal effective concentration: 75300 nM
Compound 4: middle estimate off by 2.2-fold (0.33 log units), on the low side, within the range that was stated.
By their numbers in this assay, from the lowest: compounds 1 and 2 (each within the scatter of the next); then compounds 4 and 3 (each within the scatter of the next).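

Cutting 2-fluoroethoxy back to methoxy gives a 2.0-fold higher number from compound 2 to compound 4 (0.31 log units; beyond the scatter) in this assay and so shows that this place on the pyridine is sensitive to the change, with the shorter group needing more compound for the effect. The earlier compounds shown here could not show this, as no two of them differed in one place only. Nothing measured here explains the step. Still open, going by these compounds, is how a longer chain, such as 3-fluoropropoxy, or an amine would behave in this place. Whether the fluorine or the extra chain carbon accounts for the step also stays open, and an ethoxy group would separate the two.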